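The source may report more compounds than this note shows. Statements on the series, on what has been measured and on what is new or still open speak of the compounds shown alone.

Measured in an ADME assay on the whole organism for pharmacokinetics, with Canis familiaris (Canis lupus familiaris) as the target, read by LC-MS, at a dose of 3 mg/kg by the oral route; on this read-out lower numbers stand for lower oral bioavailability and higher numbers for higher oral bioavailability:
- compound 1 `Cc1cc(C(=O)N[C@H]2CCCCC/C=C\[C@@H]3C[C@@]3(C(=O)NS(=O)(=O)C3CC3)NC(=O)[C@@H]3C[C@@H](Oc4nc5cc(F)ccc5nc4C)CN3C2=O)no1`: 123%
- compound 2 `Cc1cc(C(=O)N[C@H]2CCCCC/C=C\[C@@H]3C[C@@]3(C(=O)NS(=O)(=O)C3CC3)NC(=O)[C@@H]3C[C@@H](Oc4nc5cc(F)ccc5nc4C(F)(F)F)CN3C2=O)no1`: 74%

Of these two numbers, the lower belongs to compound 2, which gives 74% and stands well under compound 1. The next compound to be tested is compound 3 `Cc1cc(C(=O)N[C@H]2CCCCC/C=C\[C@@H]3C[C@@]3(C(=O)NS(=O)(=O)C3(C)CC3)NC(=O)[C@@H]3C[C@@H](Oc4nc5cc(F)ccc5nc4C(F)(F)F)CN3C2=O)no1`. It keeps everything in compound 2 except for one change on the cyclopropylsulfonyl group, which becomes (1-methylcyclopropyl)sulfonyl: methyl in place of hydrogen on a saturated ring carbon. In words, this is methyl in place of hydrogen on a saturated ring carbon.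

Going by the values given here, only one measured step is available, a number 49 percentage points lower from compound 1 to compound 2 (beyond the scatter). It was large, but it is trifluoromethyl in place of methyl on an aromatic carbon, a different change in a different place. Among the compounds with values here, no measured pair shows what a methyl on this three-membered ring does in this assay, so that step gives neither a size nor a direction for the new change. The working expectation is therefore no shift beyond the scatter, held with wide uncertainty. The expected move is a number 4 percentage points lower from compound 2 to compound 3 (within the scatter). For compound 3 the estimated value is 70%, with an expected range from 42% to 100%.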

Compound 3, oral bioavailability: 88%
Compound 3: middle estimate off by 18 percentage points, on the low side; the measured number falls inside the stated range.
By their numbers in this assay, from the lowest: compound 2; then compound 3; then compound 1.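

In this assay, going by these compounds alone, the change from cyclopropylsulfonyl to (1-methylcyclopropyl)sulfonyl gives a number 14 percentage points higher from compound 2 to compound 3 (beyond the scatter) and so provides the only measured reading at this position. Within the data shown here, the one step available before it concerned trifluoromethyl in place of methyl on an aromatic carbon, so this result shows that a change at the sulfonyl end of the molecule can also move oral bioavailability beyond the scatter, and here a single added methyl on the saturated ring carbon moves the number up rather than down. Nothing at hand bears on the origin of this rise.

Going by these compounds, the methyl on the three-membered ring appears here only alongside the trifluoromethyl group, so it remains open whether the same change would give a step of similar size and direction alongside the methyl group carried by compound 1. Also open, on these data alone, is what a different group on that ring carbon, such as ethyl, fluorine or an aminomethyl group, would do to the number, and so whether this effect is particular to methyl.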